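The source may hold more compounds than are shown below. What is called first, only, known or untested is meant among the compounds shown, and "the series" means these compounds.

In a functional assay on A549 cells (Homo sapiens) for cytotoxicity, read by MTT assay, with a stated time of 72 h (on this read-out higher numbers stand for weaker inhibition and lower numbers for stronger inhibition), compound 1 `COc1cc(/C=C/C(=O)Nc2cc3c(Nc4ccc(F)c(Cl)c4)ncnc3cc2O[C@H]2CCOC2)cc(OC)c1OC` gives 4150 nM. Going by the values given here, this is the lower of the two numbers available so far, because compound 2 `COc1ccc(/C=C/C(=O)Nc2cc3c(Nc4ccc(F)c(Cl)c4)ncnc3cc2OC)c(OC)c1` gives 33300 nM, and that gap lies beyond the usual scatter of repeated measurements. The next compound to be tested is compound 3 `COc1ccc(/C=C/C(=O)Nc2cc3c(Nc4ccc(F)c(Cl)c4)ncnc3cc2O[C@H]2CCOC2)c(OC)c1OC`. It has the same atoms as compound 1, joined differently: 2,3,4-trimethoxyphenyl in place of 3,4,5-trimethoxyphenyl on a double-bonded chain carbon bound to a double-bonded chain carbon. Among the compounds with values here, no two measured compounds differ in one place only, so the data offer no direct guide to this change in this assay. With so little to go on, only a small move toward weaker inhibition, within the scatter, is expected. The estimated change is a 1.4-fold higher number from compound 1 to compound 3 (0.16 log units; within the scatter). For compound 3, the expected value is 6000 nM, with an estimated range from 2000 nM to 20000 nM.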

Compound 3, half-maximal inhibitory concentration: 70 nM
Compound 3: middle estimate off by 86-fold (1.93 log units), on the high side; measured number outside the range, below it.
By their numbers in this assay, from the lowest: compound 3; then compound 1; then compound 2.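

In this assay, 2,3,4-trimethoxyphenyl in place of 3,4,5-trimethoxyphenyl gives a 59-fold lower number from compound 1 to compound 3 (1.77 log units; beyond the scatter) and so turns a weak compound into a far stronger one. The atoms and the counted features of the group stay the same, which shows that at this position the arrangement of the three methoxy groups on the ring matters a great deal, not merely their presence. Nothing at hand explains why this rearrangement has so large an effect.

Compound 2 differs from compound 1 and compound 3 in more than one place, so it cannot show which methoxy group accounts for the step. Going by these compounds, whether a hydroxyl group or an amine could replace any of these methoxy groups and keep the low number remains open.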